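Cyano in Place of Trifluoromethyl: An Expected Step

The compounds below may be only part of what the source reports. "The series", "measured", "known", "first", "only" and "open" are said of these compounds alone.

The two measured compounds share one core. Compound 1 `Clc1ccccc1-c1ccc2[nH]ncc2c1` carries a chloro on the aromatic carbon in question, and in an assay on CHO-TREX cells for antagonist activity at transient receptor potential cation channel subfamily A member 1 (Homo sapiens), read by FLIPR and calcium flux, with a stated time of 10 min (on this read-out higher numbers stand for weaker inhibition and lower numbers for stronger inhibition), compound 1 gives 1230 nM. Compound 2 `FC(F)(F)c1ccccc1-c1ccc2[nH]ncc2c1` carries a trifluoromethyl in that place, and in this assay compound 2 gives 164 nM. Among the measured compounds shown here, the only measured step is a 7.5-fold lower number from compound 1 to compound 2 (0.88 log units; beyond the scatter), and it leaves compound 2 with the lower of the two numbers; its nearest neighbour in value is compound 1.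

Compound 3 `N#Cc1ccccc1-c1ccc2[nH]ncc2c1` has not been measured. It differs from compound 2 by cyano in place of trifluoromethyl on an aromatic carbon. For the measured compounds named here, no measured pair exchanges trifluoromethyl for cyano, so the measured step bears on it only indirectly: the step from compound 1 to compound 2 shows that changing the group at this aromatic carbon can move the number well beyond the scatter, and that among the groups tried, trifluoromethyl gives the lower number. Compound 3 is therefore expected to return a higher number than compound 2, a step of a 3.7-fold higher number from compound 2 to compound 3 (0.56 log units; beyond the scatter), with an estimate of 600 nM and a range from 200 nM to 2500 nM in this assay.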

Compound 3, half-maximal inhibitory concentration: 1290 nM
Compound 3: middle estimate off by 2.2-fold (0.33 log units), on the low side, and the stated range covers the measured number.
By their numbers in this assay, from the lowest: compound 2; then compounds 1 and 3 (each within the scatter of the next).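

In this assay, cyano in place of trifluoromethyl on this aromatic carbon gives a 7.9-fold higher number from compound 2 to compound 3 (0.90 log units; beyond the scatter) and so supplies the first direct measure of what is lost when trifluoromethyl leaves this place, a step about as large as the one that separated chloro from trifluoromethyl earlier. The new compound also shows that two quite different groups can read alike here, since a 1.0-fold higher number from compound 1 to compound 3 (0.02 log units; within the scatter) leaves cyano and chloro within the scatter of each other, although cyano brings a triple bond and a hydrogen-bond acceptor that chloro lacks. Among the three groups tried at this carbon, trifluoromethyl alone stands apart, and compound 2 is now the strongest of the set, with its steps to both other compounds printed as beyond the scatter.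

The compounds shown leave open whether a methoxy group, an amine, a carboxylic acid or a longer chain such as ethyl on this carbon would match trifluoromethyl or fall with chloro and cyano. No evidence is at hand that bears on why trifluoromethyl stands apart from the other two groups.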